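Chloro-to-methyl swap carried over to a second core

The source may report more compounds than this note shows. Statements on the series, on what has been measured and on what is new or still open speak of the compounds shown alone.

Compound 1 `COc1ncc(-c2ccc3nc(NC(C)=O)nn3c2)cc1NS(=O)(=O)c1ccc(Cl)cc1` and compound 2 `COc1ncc(-c2ccc3nc(NC(C)=O)nn3c2)cc1NS(=O)(=O)c1ccc(C)cc1` share one core; compound 3 `COc1ncc(-c2ccn3nc(NC(C)=O)nc3c2)cc1NS(=O)(=O)c1ccc(Cl)cc1` and the unmeasured compound 4 `COc1ncc(-c2ccn3nc(NC(C)=O)nc3c2)cc1NS(=O)(=O)c1ccc(C)cc1` share another, and the difference between the two cores is not broken down here. In a functional assay on MCF7 cells (Homo sapiens) for antiproliferative activity, read by MTT assay, with a stated time of 48 h (a higher number here means a weaker inhibitor, a lower number a stronger inhibitor), compound 1 gives 2010 nM, and compound 2 gives 810 nM. The step between them, a 2.5-fold lower number from compound 1 to compound 2 (0.39 log units; beyond the scatter), comes from the change (methyl in place of chloro on an aromatic carbon). In this assay, for the measured compounds named here, compound 3 gives 1240 nM; set beside compound 2 the two numbers lie within the scatter, and the same holds for compound 3 beside compound 1, so the only step read beyond the scatter among the measured compounds is that from compound 1 to compound 2.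

Compound 4 differs from compound 3 by methyl in place of chloro on an aromatic carbon, the same change as that from compound 1 to compound 2, at the same place on the sulfonyl-bearing ring. The swap is seen only once among the measured pairs, so any expectation rests on a single precedent. For compound 4 a step of about a 2.5-fold lower number from compound 3 to compound 4 (0.39 log units; beyond the scatter) is expected in this assay. Going by the values given here, the expectation rests on compound 1 and compound 2, because a 2.5-fold lower number from compound 1 to compound 2 (0.39 log units; beyond the scatter) is the only measured instance of this swap, and the transfer to another core is untested. The estimated value for compound 4 in this assay is 500 nM, with a range from 250 nM to 1000 nM, kept wide for that reason.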

Compound 4, half-maximal inhibitory concentration: 1360 nM
For compound 4 the middle estimate is 2.7-fold (0.43 log units) below the measured one; the whole stated range lies below it.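

Carried to the second core, the change from 4-chlorophenyl to 4-methylphenyl gives in this assay a 1.1-fold higher number from compound 3 to compound 4 (0.04 log units; within the scatter), so the step read beyond the scatter on the core of compound 1 does not recur on this core. For this one change, the step read on one core therefore did not hold on the other, and the two steps differ: the same change on two cores in this assay, a 2.5-fold lower number (0.39 log units; beyond the scatter) from compound 1 to compound 2 and a 1.1-fold higher number (0.04 log units; within the scatter) from compound 3 to compound 4, 2.7-fold (0.43 log units) apart, beyond the scatter of two such steps

This does not show which feature of the two cores goes with the gap, since the difference between them is not broken down, and two pairs, each measured once in a single cell line, give no general rule for the series.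

Open, on these data alone, is whether a nitrile or an amine at the place held by chloro and methyl would also give steps that differ between the two cores, or whether the gap is confined to this one swap. Also open, as far as these compounds go, is whether the gap persists when the acetamide common to all four compounds gives way to a longer chain or a carboxylic acid.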